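Side chain swap at the ether: compound 2 to compound 3

A few compounds are considered here, and "the series" means these few. Any claim that something is new, unique, unknown or untested is made for them only; others in the source may bear on it.

Measured so far in a toxicity assay on MT2 cells (Homo sapiens) for cytotoxicity, read by XTT assay, with a stated time of 4 days; a higher number here means that more compound is tolerated, a lower number that less compound is tolerated (both values are limits):
Compound 1 (`Cc1cc(CCOc2ccc(-c3c(C)nc(C)c([C@H](OC(C)(C)C)C(=O)O)c3N3CCC(C)(C)CC3)cc2)ccc1F`): >= 33500 nM
Compound 2 (`Cc1nc(C)c([C@H](OC(C)(C)C)C(=O)O)c(N2CCC(C)(C)CC2)c1-c1ccc(OCCCc2ccc(F)cc2)cc1`): >= 32000 nM

In this assay compound 2 gives only a limit, >= 32000 nM, and no number. The other value in the series is a limit as well, so compound 2 cannot be ranked.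

Compound 3 (`Cc1nc(C)c([C@H](OC(C)(C)C)C(=O)O)c(N2CCC(C)(C)CC2)c1-c1ccc(OCCc2cccnc2)cc1`) carries pyridin-3-yl in place of 4-fluorobenzyl on a saturated chain carbon, two bonds along the chain from an oxygen on an aromatic ring. The side chain thus reads 2-(pyridin-3-yl)ethoxy instead of 3-(4-fluorophenyl)propoxy.

Going by the values given here, the only measured change at this place is a step that the two limits leave unreadable from compound 1 to compound 2, so it offers no size to carry over. No step beyond the usual scatter can be argued for in this assay, and no direction is expected. Compound 3 may well be reported as a limit too.

The step expected is a number no higher from compound 2 to compound 3 (the limit leaves the size open), an estimate only. The estimated value for compound 3 is 32000 nM, with an expected range from 14000 nM to 70000 nM.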

Compound 3, half-maximal cytotoxic concentration: >= 25000 nM
Compound 3 gave a limit, no number; the forecaster's own chance of this, stated with the estimate: 70%; the middle value is on the limit's open side.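

In this assay compound 3 gives >= 25000 nM, which is a limit and not a number. Going by these compounds alone, compound 1, compound 2 and compound 3 all stand as limits, so no step among them can be read. The compounds shown leave open where the half-maximal cytotoxic concentration of each actually lies, and whether pyridin-3-yl in place of 4-fluorobenzyl shifts it at all.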